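A few compounds are considered here, and "the series" means these few. Any claim that something is new, unique, unknown or untested is made for them only; others in the source may bear on it.

Values in a functional assay on the whole organism (artery, strain albino) with Rattus norvegicus as the target, with a stated time of 900 min, at a dose of 10 mg/kg by the oral route; on this read-out lower numbers stand for less inhibition and higher numbers for more inhibition at the one dose given (going by the name of the read-out):

compound 1 `COc1ccc(C2N=C(SCc3ccccc3)NC(C)=C2C(=O)Nc2ccc(F)cc2)cc1OC`: 1%
compound 2 `COc1ccc(C2N=C(SCc3ccccc3Cl)NC(C)=C2C(=O)Nc2ccc(F)cc2)cc1OC`: 21%
compound 3 `CC1=C(C(=O)Nc2ccc(F)cc2)C(c2ccc([N+](=O)[O-])cc2)N=C(SCc2ccccc2)N1`: 21%

Compound 3 stands level with compound 2 at the digits shown, the two of them sharing the highest reading among the three; its only partner beyond the scatter is compound 1, from which it is separated by the step of a number 20 percentage points higher from compound 1 to compound 3 (beyond the scatter). That step consists of putting 4-nitrophenyl in place of 3,4-dimethoxyphenyl on the saturated ring carbon of the shared core.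

Compound 4 `CC1=C(C(=O)Nc2ccc(F)cc2)C(c2ccc([N+](=O)[O-])cc2)N=C(SCc2ccccc2Cl)N1` has not yet been measured. It differs from compound 3 in one place: chloro in place of hydrogen on an aromatic carbon The same change has been seen once before in this set, on the benzylsulfanyl group of compound 1, and it produced the step of a number 20 percentage points higher from compound 1 to compound 2 (beyond the scatter). Going by the values given here, that is the only measured step that bears on the present one, and it was modest but beyond the scatter. A step of similar size and direction is therefore the natural expectation for compound 4, with the caution that a single precedent on a different aryl partner is a thin basis.

The expected step is a number 15 percentage points higher from compound 3 to compound 4 (beyond the scatter). Compound 4 is accordingly estimated at 36%, within a range from 15% to 60%.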

Compound 4, a percentage reported as inhibition, in the whole organism at one dose (the size of the read-out at that dose, not a potency): 11.3%
Compound 4: middle estimate off by 24.7 percentage points, on the high side; the whole stated range lies above it.
By their numbers in this assay, from the lowest: compound 1; then compounds 4, 2 and 3 (each within the scatter of the next).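

In this assay, chloro in place of hydrogen on the aromatic carbon of the benzylsulfanyl group does not bring a constant step: with 4-nitrophenyl on the saturated ring carbon it gives a number 9.7 percentage points lower from compound 3 to compound 4 (within the scatter), so the gain seen with 3,4-dimethoxyphenyl does not carry over, and the two steps disagree by more than the scatter allows: the same change on two cores in this assay, a number 20 percentage points higher (beyond the scatter) from compound 1 to compound 2 and a number 9.7 percentage points lower (within the scatter) from compound 3 to compound 4, 29.7 percentage points apart, beyond the scatter of two such steps

The change from 3,4-dimethoxyphenyl to 4-nitrophenyl depends in the same way on its partner: with (2-chlorobenzyl)sulfanyl in place of benzylsulfanyl it gives a number 9.7 percentage points lower from compound 2 to compound 4 (within the scatter), unlike the rise it gave in the unsubstituted benzyl series: the same change on two cores in this assay, a number 20 percentage points higher (beyond the scatter) from compound 1 to compound 3 and a number 9.7 percentage points lower (within the scatter) from compound 2 to compound 4, 29.7 percentage points apart, beyond the scatter of two such steps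

The two places therefore do not add up independently across these four compounds, and the outcome of a change at either one has to be read together with the group at the other.

The compounds shown leave open whether this dependence is particular to chloro or would also appear with a methoxy or trifluoromethyl group on the same aromatic carbon, and how an amine or a carboxylic acid would behave in place of the nitro group of the 4-nitrophenyl ring. With readings at one dose only, they also cannot say whether the same dependence would hold at other doses.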